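A few compounds are considered here, and "the series" means these few. Any claim that something is new, unique, unknown or untested is made for them only; others in the source may bear on it.

Compound 1 `O=C(NOCc1ccccc1F)c1cn(-c2ccccc2)nc1-c1ccccc1`: 11800 nM
Compound 2 `O=C(NOCc1ccccc1Cl)c1cn(-c2ccccc2)nc1-c1ccccc1`: 17800 nM

In a functional assay on HeLa cells (Homo sapiens) for antiproliferative activity, read by MTT assay, with a stated time of 48 h, in the presence of a further agent that is not named here (on this read-out higher numbers stand for weaker inhibition of growth and lower numbers for stronger inhibition of growth), compound 2 gives 17800 nM, and compound 1 gives 11800 nM; the two numbers lie within the scatter of each other, so neither stands apart. Compound 3 `O=C(NOCc1ccccc1Cl)c1cn(-c2ccccc2)nc1-c1ccc(Cl)cc1` differs from compound 2 by chloro in place of hydrogen on an aromatic carbon. Within the data shown here, the only measured step, a 1.5-fold higher number from compound 1 to compound 2 (0.18 log units; within the scatter), exchanges one halogen for another at a different place on the molecule, so it does not directly inform this addition; nothing measured points to a change beyond the scatter. For compound 3 the expected step is therefore a 1.2-fold lower number from compound 2 to compound 3 (0.07 log units; within the scatter). Compound 3 is estimated at 15000 nM, with a range from 5000 nM to 45000 nM.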

Compound 3, concentration for 50% growth inhibition: 8850 nM
Beside the measured number, compound 3's estimate is 1.7-fold (0.23 log units) above it; the range from low to high includes it.
By their numbers in this assay, from the lowest: compounds 3, 1 and 2 (each within the scatter of the next).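

In this assay, going from phenyl to 4-chlorophenyl gives a 2.0-fold lower number from compound 2 to compound 3 (0.30 log units; within the scatter). Among these compounds, this is the first measured change at this position, since the earlier pair differed elsewhere on the molecule, and it shows that chloro can sit here, para to a large group, with no shift beyond the scatter. Nothing available here accounts for the size of this step.

Going by these compounds, whether an amine or a methoxy group at this place would move the number beyond the scatter stays open. So does whether the same chloro would give a similar step on compound 1.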